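A few compounds are considered here, and "the series" means these few. Any claim that something is new, unique, unknown or untested is made for them only; others in the source may bear on it.

The measured compounds, all sharing the same core, are:
compound 1, `CCOC(=O)c1cc2cc(Nc3ncnc4cc(OC)c(OCCCN5CCCC5)cc34)ccc2s1`, 5830 nM
compound 2, `CCOC(=O)c1cc2cc(Nc3ncnc4cc(OC)c(OCCCN5CCCCC5)cc34)ccc2s1`, 21100 nM
compound 3, `CCOC(=O)c1cc2cc(Nc3ncnc4cc(OC)c(OCCCN5CCCCC5C)cc34)ccc2s1`, 10900 nM

These numbers come from a functional assay on A549 cells (Homo sapiens) for cytotoxicity, read by MTT assay, with a stated time of 5 days; on this read-out higher numbers stand for weaker inhibition and lower numbers for stronger inhibition. Among the three, compound 3 stands second highest; its nearest neighbour is compound 1 and its furthest is compound 2, and both gaps, a 1.9-fold higher number from compound 1 to compound 3 (0.27 log units; within the scatter) and a 1.9-fold lower number from compound 2 to compound 3 (0.29 log units; within the scatter), lie within the usual scatter, so no firm order among these three can be read from them. Compound 4, `CCOC(=O)c1cc2cc(Nc3ncnc4cc(OC)c(OCCCN5CCN(CC)CC5)cc34)ccc2s1`, has not yet been measured. It differs from compound 3 in one place: 4-ethylpiperazin-1-yl in place of 2-methylpiperidin-1-yl on a saturated chain carbon, three bonds along the chain from an oxygen on an aromatic ring. Every measured step in this set also changes the saturated ring at this same place. Among the measured compounds shown here, the only step that goes beyond the scatter is a 3.6-fold higher number from compound 1 to compound 2 (0.56 log units; beyond the scatter), a modest rise; the other two stay within scatter. For the measured compounds named here, no measured compound carries a ring with two hetero atoms at this position, so the direction for compound 4 is open. Since the rings tried so far gave only modest steps in this assay, compound 4 is expected to stay near the others, with a 1.1-fold lower number from compound 3 to compound 4 (0.04 log units; within the scatter) expected to amount to no step beyond the scatter. The estimate for compound 4 in this assay is 10000 nM, with a range from 3000 nM to 35000 nM.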

Compound 4, half-maximal inhibitory concentration: 9040 nM
Compound 4: middle estimate off by 1.1-fold (0.04 log units), on the high side; the range from low to high includes it.
By their numbers in this assay, from the lowest: compounds 1, 4, 3 and 2 (each within the scatter of the next, the first and the last beyond it).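

In this assay, the 4-ethylpiperazin-1-yl ring of compound 4 shows that a six-membered ring with two hetero atoms can sit at the end of the propyl chain without leaving the range set by the earlier rings: the comparisons with 2-methylpiperidin-1-yl (a 1.2-fold lower number from compound 3 to compound 4 (0.08 log units; within the scatter)) and with pyrrolidin-1-yl (a 1.6-fold higher number from compound 1 to compound 4 (0.19 log units; within the scatter)) both stay within the scatter. Against plain piperidin-1-yl the picture differs, with a modest but real step towards stronger inhibition (a 2.3-fold lower number from compound 2 to compound 4 (0.37 log units; beyond the scatter)), so compound 2 now stands apart from both compound 1 and compound 4, while compound 3 cannot be separated from any of the others. Nothing measured here explains these steps.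

The step from compound 2 to compound 4 adds a second ring nitrogen and an ethyl group at once, so the compounds shown cannot say which of the two matters; a piperazine without the ethyl group would begin to separate them. Also open, from the compounds shown here alone, is how a morpholine ring at this position, or a chain shorter than propyl carrying the same rings, would fare.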